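Replacing a Dichlorobenzyl Group with a Phenylthiourea

A few compounds are considered here, and "the series" means these few. Any claim that something is new, unique, unknown or untested is made for them only; others in the source may bear on it.

Compound 1 `NC(=O)c1c(NC(=O)c2ccccc2Cl)sc2c1CCN(Cc1ccccc1Cl)C2`: 2900 nM
Compound 2 `NC(=O)c1c(NC(=O)c2ccccc2Cl)sc2c1CCN(Cc1c(Cl)cccc1Cl)C2`: 4850 nM
Compound 3 `NC(=O)c1c(NC(=O)c2ccccc2Cl)sc2c1CCN(Cc1ccc(Cl)cc1Cl)C2`: 8010 nM

In a functional assay on HL-60 cells (Homo sapiens) for antiproliferative activity, with a stated time of 24 h (on this read-out higher numbers stand for weaker inhibition and lower numbers for stronger inhibition), compound 3 gives 8010 nM, the highest of the three numbers. The step of a 2.8-fold higher number from compound 1 to compound 3 (0.44 log units; beyond the scatter) lies beyond the scatter, whereas a 1.7-fold higher number from compound 2 to compound 3 (0.22 log units; within the scatter) does not. Compound 4 `NC(=O)c1c(NC(=O)c2ccccc2Cl)sc2c1CCN(C(=S)Nc1ccccc1)C2` differs from compound 3 by a group of 9 heavy atoms (7 carbon, 1 nitrogen, 1 sulfur; one six-membered aromatic ring of carbon only) in place of a group of 9 heavy atoms (7 carbon, 2 chlorine; one six-membered aromatic ring of carbon only), on an amine nitrogen in a ring. Within the data shown here, none of the measured steps touches a change of this kind: a 1.7-fold higher number from compound 1 to compound 2 (0.22 log units; within the scatter) and a 2.8-fold higher number from compound 1 to compound 3 (0.44 log units; beyond the scatter) each add a chloro substituent to the benzyl ring, and a 1.7-fold higher number from compound 2 to compound 3 (0.22 log units; within the scatter) moves one, so all three keep a benzyl group on that nitrogen. Among the measured compounds shown here, with no step to lean on, the expected direction in this assay is open, and the estimate is placed near compound 3 with a broad range. Compound 4 is therefore expected to give 6000 nM (range 1500 nM to 25000 nM), an expected step of a 1.3-fold lower number from compound 3 to compound 4 (0.13 log units; within the scatter).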

Compound 4, half-maximal inhibitory concentration: 5940 nM
Compound 4: the middle estimate sits 1.0-fold (0.00 log units) above what was measured; measured number inside the range.
By their numbers in this assay, from the lowest: compounds 1, 2, 4 and 3 (each within the scatter of the next, the first and the last beyond it).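

In this assay the amine nitrogen in a ring accepts a phenylthiourea in place of a benzyl group with little consequence, as a 1.3-fold lower number from compound 3 to compound 4 (0.13 log units; within the scatter) and a 1.2-fold higher number from compound 2 to compound 4 (0.09 log units; within the scatter) show, and only a 2.0-fold higher number from compound 1 to compound 4 (0.31 log units; beyond the scatter) exceeds the scatter, and modestly. The benzyl group is therefore not required at this position for a number in this range. No measurement at hand explains these numbers. As far as these compounds go, it remains open how the corresponding urea, with oxygen in place of sulfur, or a chloro substituent on the phenyl ring of the thiourea would read here.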